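The compounds below may be only part of what the source reports. "The series", "measured", "known", "first", "only" and "open" are said of these compounds alone.

Values in a toxicity assay on L02 cells (Homo sapiens) for cytotoxicity, read by MTT assay, with a stated time of 72 h; a lower number here means a stronger inhibitor, a higher number a weaker inhibitor:
- compound 1 `CN(C)CCCCCn1c2c(c3ccccc31)C(=O)c1c[n+]([O-])c3ccccc3c1C2=O`: 240 nM
- compound 2 `O=C1c2c[n+]([O-])c3ccccc3c2C(=O)c2c1c1ccccc1n2Cc1cn(C[C@H](O)CO)nn1`: 1130 nM
- compound 3 `O=C1c2c[n+]([O-])c3ccccc3c2C(=O)c2c1c1ccccc1n2Cc1cn(CC(O)CO)nn1`: 1070 nM

Compound 3, at 1070 nM, sits at the upper end of this small set. It cannot be told apart from compound 2, since the step of a 1.1-fold lower number from compound 2 to compound 3 (0.02 log units; within the scatter) concerns only (the fact that one of compounds 2 and 3 is drawn with a defined configuration and the other without, at the place where they differ). That step therefore offers no guide to what comes next.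

The next compound is compound 4 `O=C1c2c[n+]([O-])c3ccccc3c2C(=O)c2c1c1ccccc1n2CCCCN1CCNCC1`, which differs from compound 3 as follows: 3-(piperazin-1-yl)propyl in place of 1-(2,3-dihydroxypropyl)-1H-1,2,3-triazol-4-yl on a saturated chain carbon bound to an aromatic nitrogen. In words, 3-(piperazin-1-yl)propyl stands in place of 1-(2,3-dihydroxypropyl)-1H-1,2,3-triazol-4-yl on a saturated chain carbon bound to an aromatic nitrogen.

The useful comparison is with compound 1, which carries 4-(dimethylamino)butyl at that place and gives 240 nM. Two measured steps swap that group for the same triazole group: a 4.7-fold higher number from compound 1 to compound 2 (0.67 log units; beyond the scatter) and a 4.5-fold higher number from compound 1 to compound 3 (0.65 log units; beyond the scatter). Compound 4 moves the opposite way, away from the triazole group and back to a group with an amine, though not the same one. A partial return towards compound 1 therefore seems reasonable, with some doubt left by the different group.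

The expected change is a 3.1-fold lower number from compound 3 to compound 4 (0.49 log units; beyond the scatter), a lower number in this assay.

Compound 4 is estimated at 350 nM, with an expected range of 130 nM to 950 nM.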

Compound 4, half-maximal inhibitory concentration: 1380 nM
Compound 4: the middle estimate sits 3.9-fold (0.60 log units) below what was measured; the measured number lies above the stated range.
By their numbers in this assay, from the lowest: compound 1; then compounds 3, 2 and 4 (each within the scatter of the next).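

In this assay, an amine-bearing chain at this place does not by itself bring the number down: a 1.3-fold higher number from compound 3 to compound 4 (0.11 log units; within the scatter) and a 1.2-fold higher number from compound 2 to compound 4 (0.09 log units; within the scatter) both leave the 3-(piperazin-1-yl)propyl group indistinguishable from the triazole group. Compound 1 remains apart, with a 5.8-fold higher number from compound 1 to compound 4 (0.76 log units; beyond the scatter), a step in which piperazin-1-yl stands in place of (dimethylamino)methyl on a saturated chain carbon, four bonds along the chain from an aromatic nitrogen. Among these four compounds, then, an amine on the chain is not enough to match compound 1, and compound 4 goes against any rule that links the amine alone to the lower number.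

A 3-(dimethylamino)propyl group at the same place would help separate the effect of the piperazine ring from that of the chain, while a 4-(4-methylpiperazin-1-yl)butyl group would test a further change to the ring. The data shown give no measured property that accounts for the gap between compound 1 and compound 4.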